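The source may report more compounds than this note shows. Statements on the series, on what has been measured and on what is new or still open speak of the compounds shown alone.

Working notes, values in an ADME assay on L6 cells (Rattus norvegicus) for cytotoxicity, read by resazurin assay, with a stated time of 72 h; a lower number here means a stronger inhibitor, a higher number a weaker inhibitor:

- compound 1 `Cc1ccc(C(O)(c2ccc(Cl)cc2)c2cccnc2)cc1`: 61000 nM
- compound 2 `OC(c1ccc(Cl)cc1)(c1ccc(C(F)(F)F)cc1)c1cccnc1`: 56400 nM

Compound 2 stands level with compound 1, with trifluoromethyl in place of methyl on an aromatic carbon giving a 1.1-fold lower number from compound 1 to compound 2 (0.03 log units; within the scatter). The next compound is compound 3 `OC(c1ccc(Br)cc1)(c1ccc(C(F)(F)F)cc1)c1cccnc1`: bromo in place of chloro on an aromatic carbon, para to a large group. Among the compounds with values here, no measured step involves this swap. Within the data shown here, the only guide is a 1.1-fold lower number from compound 1 to compound 2 (0.03 log units; within the scatter), a change of another group, so no step beyond the scatter is expected in this assay. The expected step is a 1.1-fold lower number from compound 2 to compound 3 (0.05 log units; within the scatter). Compound 3 is estimated at 50000 nM, with an expected range of 26000 nM to 90000 nM.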

Compound 3, half-maximal inhibitory concentration: 54700 nM
Estimate against measurement, compound 3: 1.1-fold (0.04 log units) below; the range from low to high includes it.
By their numbers in this assay, from the lowest: compounds 3, 2 and 1 (each within the scatter of the next).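

In this assay the change from 4-chlorophenyl to 4-bromophenyl gives no separation (a 1.0-fold lower number from compound 2 to compound 3 (0.01 log units; within the scatter)). This adds the position para to a large group to the earlier trifluoromethyl-for-methyl change as a second place where a single swap stays within the scatter. No measurement on hand accounts for this result.

Going by these compounds, whether an amine, a carboxylic acid or a nitrile at this position would move the number remains open. Also open, on these data alone, is whether any change to the shared core gives a step beyond the scatter.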